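Methyl on the core ring: compound 4 from compound 2

The source may report more compounds than this note shows. Statements on the series, on what has been measured and on what is new or still open speak of the compounds shown alone.

Among the measured compounds shown here, compound 2 `O=S(=O)(c1ccccc1)N1CCOc2c(N3CCNCC3)cccc21` gives 12.6 nM in an assay on HEK293 cells for displacement of a labelled ligand from 5-hydroxytryptamine receptor 6 (Homo sapiens) (on this read-out lower numbers stand for stronger inhibition and higher numbers for weaker inhibition), and stands second highest of the three numbers measured so far. Compound 1 `O=S(=O)(c1c(Cl)cccc1Cl)N1CCOc2c(N3CCNCC3)cccc21` gives 0.0631 nM; compound 3 `CS(=O)(=O)c1ccccc1S(=O)(=O)N1CCOc2c(N3CCNCC3)cccc21` gives 316 nM. The two known steps, a 200-fold higher number from compound 1 to compound 2 (2.30 log units; beyond the scatter) and a 25-fold higher number from compound 2 to compound 3 (1.40 log units; beyond the scatter), both alter the aryl on the sulfonyl sulfur and leave the shared core untouched. Compound 4 `Cc1cc(N2CCNCC2)c2c(c1)N(S(=O)(=O)c1ccccc1)CCO2` differs from compound 2 by methyl in place of hydrogen on an aromatic carbon. For the measured compounds named here, no measured step concerns this ring, so neither known step bears on the change directly; the expected shift is smaller than either and probably within the scatter. Compound 4 is therefore estimated at 12 nM, range 3.5 nM to 40 nM, an expected step of a 1.1-fold lower number from compound 2 to compound 4 (0.02 log units; within the scatter).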

Compound 4, inhibition constant: 2.51 nM
The estimate for compound 4 lay 4.8-fold (0.68 log units) above the measured number; measured number outside the range, below it.
By their numbers in this assay, from the lowest: compound 1; then compound 4; then compound 2; then compound 3.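

Under this assay methyl in place of hydrogen gives a 5.0-fold lower number from compound 2 to compound 4 (0.70 log units; beyond the scatter) on an aromatic carbon meta to the piperazin-1-yl group and para to a fused ring. Among the compounds shown here, the earlier steps all altered the aryl on the sulfonyl sulfur, so this is the first sign that the shared core also moves the number, though by a modest step. Nothing at hand accounts for the gain.

On these data alone, whether ethyl, methoxy or chlorine at this carbon would shift the number in the same direction remains open. So does whether the methyl would add to the 2,6-dichlorophenyl of compound 1.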